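Thiazolopyrimidine amine series: aryl replacement at the five-membered ring

This account rests on a few compounds, and the source may have more. Where it says the series, first, only, none or still open, it means among the compounds named here.

Measured compounds:
- compound 1 `Nc1nc(N2CCN(C(=O)COc3ccc(Cl)cc3)CC2)c2nc(-c3ccc(F)cc3)sc2n1`: 490 nM
- compound 2 `Nc1nc(N2CCN(C(=O)COc3ccc(Cl)cc3)CC2)c2nc(CCCCc3ccc(F)cc3)sc2n1`: 920 nM

Within the data shown here, compound 2 `Nc1nc(N2CCN(C(=O)COc3ccc(Cl)cc3)CC2)c2nc(CCCCc3ccc(F)cc3)sc2n1` stands at the higher of the two numbers in a functional assay on cells (Lymphocyte, Homo sapiens) (a higher number here means a weaker inhibitor, a lower number a stronger inhibitor), where compound 2 gives 920 nM; its only neighbour is compound 1, and the gap between them is within the scatter, so no order between the two is established. Among the measured compounds shown here, the one measured step, a 1.9-fold higher number from compound 1 to compound 2 (0.27 log units; within the scatter), is the step from the directly attached 4-fluorophenyl to the 4-(4-fluorophenyl)butyl chain, and it did not reach beyond the scatter.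

Compound 3 `Nc1nc(N2CCN(C(=O)COc3ccc(Cl)cc3)CC2)c2nc(-c3ccc(Cl)cc3)sc2n1` differs from compound 2 as follows: 4-chlorophenyl in place of 4-(4-fluorophenyl)butyl on an aromatic carbon. Compound 3 thus returns to a directly attached aryl group, now the 4-chlorophenyl, at the same place on the five-membered aromatic ring with nitrogen and sulfur. For the measured compounds named here, the only step that bears on this change is the one above, which runs in the opposite direction and was small. Going by the values given here, no measured pair tells anything about fluorine against chlorine on that aryl ring. For compound 3 the expected step is therefore a 2.0-fold lower number from compound 2 to compound 3 (0.31 log units; beyond the scatter) in this assay, a move back toward the number of compound 1 and not clearly beyond the scatter. The estimate for compound 3 is 450 nM, with a range from 150 nM to 1400 nM.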

Compound 3, half-maximal inhibitory concentration: 270 nM
For compound 3 the middle estimate is 1.7-fold (0.22 log units) above the measured one, and the stated range covers the measured number.
By their numbers in this assay, from the lowest: compounds 3, 1 and 2 (each within the scatter of the next, the first and the last beyond it).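

In this assay, this position now has a step beyond the scatter: a 3.4-fold lower number from compound 2 to compound 3 (0.53 log units; beyond the scatter). Compound 1 and compound 2 alone could not separate a directly attached aryl group from the long chain, whereas the 4-chlorophenyl of compound 3 is separated from the 4-(4-fluorophenyl)butyl of compound 2, although this step changes the chain and the halogen together. The change of halogen on the directly attached aryl ring can be read by itself, and a 1.8-fold lower number from compound 1 to compound 3 (0.26 log units; within the scatter) leaves chloro and fluoro unordered at this place, while no measurement offered here accounts for the gap between compound 2 and compound 3.

Still open, on these data alone, is whether the butyl chain ending in a chlorinated aryl ring would fall with compound 2 or with compound 3, which would separate the contribution of the chain from that of the halogen. A shorter chain, such as a single methylene or a two-carbon link to the aryl ring, and a bromo or methoxy group in place of the halogen, would show how far this position tolerates other groups.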